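The source may report more compounds than this note shows. Statements on the series, on what has been measured and on what is new or still open speak of the compounds shown alone.

Three analogues sharing one core have been run in an ADME assay on MT4 cells (Homo sapiens) for cytotoxicity, read by MTT assay; a higher number here means that more compound is tolerated, a lower number that less compound is tolerated. Compound 1 `Cc1cc(C)cc(S(=O)(=O)c2c(C(=O)NCC(=O)NCc3ccncc3)[nH]c3ccc(Cl)cc23)c1` reaches only the assay limit, giving > 48900 nM. Compound 2 `Cc1cc(C)cc(S(=O)(=O)c2c(C(=O)NC(C)C(=O)NC(C)c3ccccc3F)[nH]c3ccc(Cl)cc23)c1` gives 15200 nM. Compound 3 `Cc1cc(C)cc(S(=O)(=O)c2c(C(=O)NC(C)c3cc(F)cc(F)c3)[nH]c3ccc(Cl)cc23)c1` likewise reaches only a limit, giving > 49700 nM. Compound 3 thus stands among the values that sit at the assay ceiling, as recorded in the limit of > 49700 nM in this assay, at which 1 of the 3 values shown sits. The one readable move is an at least 3.2-fold higher number from compound 2 to compound 3 (0.51 log units; beyond the scatter), while a step that the two limits leave unreadable from compound 1 to compound 3. Compound 4 `COc1cccc(F)c1CNC(=O)c1[nH]c2ccc(Cl)cc2c1S(=O)(=O)c1cc(C)cc(C)c1` carries 2-fluoro-6-methoxybenzyl in place of 1-(3,5-difluorophenyl)ethyl on an amide-type nitrogen. For the measured compounds named here, no measured step covers this exchange; the readable step only shows that compound 3 is tolerated beyond the reach of this assay, so the expected move an at least 1.1-fold lower number from compound 3 to compound 4 (0.04 log units; that floor lies within the scatter) is none beyond the scatter, with a limit likely reported again. Compound 4 is expected at 45000 nM, within 15000 nM to 100000 nM.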

Compound 4, half-maximal cytotoxic concentration: > 49900 nM
Compound 4: only a limit was reported; the forecaster's own chance of this, stated with the estimate: 60%; middle value at least 1.1-fold (0.04 log units) from the limit.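

Compound 4 gives > 49900 nM, which is a limit. Its steps from compound 1 and compound 3, which also sit at limits, cannot be read. The compounds shown leave open how compound 1, compound 3 and compound 4 rank against one another.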